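Carboxylic Acid in Place of a Protected Amine Side Chain

The source may hold more compounds than are shown below. What is called first, only, known or untested is meant among the compounds shown, and "the series" means these compounds.

Compound 1, `CCCSc1nc(Cl)c2c(n1)N(Cc1cccs1)C(C(=O)N1CCN(C)CC1)N2`: 6420 nM
Compound 2, `CCCSc1nc(Cl)c2c(n1)N(Cc1ccccc1)C(C(=O)NCCNC(=O)OC(C)(C)C)N2`: 53200 nM
Compound 3, `CCCSc1nc(Cl)c2c(n1)N(Cc1ccco1)C(C(=O)N1CCN(C)CC1)N2`: 13600 nM

Of the compounds shown here, three built on the shared core have been measured in a functional assay on A549 cells (Homo sapiens) for antiproliferative activity, read by MTT assay, with a stated time of 72 h; a higher number here means a weaker inhibitor, a lower number a stronger inhibitor. Compound 2 gives the highest number of the three, 53200 nM, and is the weakest inhibitor in this set. Compound 3, with 13600 nM, stands nearest to it, and compound 1, with 6420 nM, furthest away. For the measured compounds named here, the only step between two compounds that differ in a single place is a 2.1-fold higher number from compound 1 to compound 3 (0.33 log units; beyond the scatter), which concerns the group on the saturated chain carbon bound to the ring nitrogen.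

Compound 4, `CCCSc1nc(Cl)c2c(n1)N(Cc1ccccc1)C(C(=O)O)N2`, differs from compound 2 at another site: hydroxy in place of (2-((tert-butoxycarbonyl)amino)ethyl)amino on a carbonyl carbon. Going by the values given here, no measured step touches the carbonyl carbon, so the one step recorded, between compound 1 and compound 3, does not bear on this change, and the direction of the effect in this assay cannot be read from the data at hand. Given that compound 2 already sits at 53200 nM, compound 4 is expected to land in the same weak region, with an estimated step of a 1.5-fold higher number from compound 2 to compound 4 (0.18 log units; within the scatter). The estimate for compound 4 is 80000 nM, within a range from 20000 nM to 300000 nM.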

Compound 4, half-maximal inhibitory concentration: 10700 nM
Estimate against measurement, compound 4: 7.5-fold (0.87 log units) above, outside the stated range (below it).
By their numbers in this assay, from the lowest: compounds 1, 4 and 3 (each within the scatter of the next, the first and the last beyond it); then compound 2.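

In this assay, for the compounds shown here, hydroxy in place of (2-((tert-butoxycarbonyl)amino)ethyl)amino on the carbonyl carbon gives a 5.0-fold lower number from compound 2 to compound 4 (0.70 log units; beyond the scatter), the first measured step at this position. It shows that the group on this carbonyl carbon matters in this assay, and that the chain of 11 heavy atoms can give way to a single hydroxy with the number falling rather than rising. The data at hand offer no measurement that would explain this step.

The compounds shown leave open which part of the departing chain accounts for the difference: the tert-butoxycarbonyl group, the ethyl chain or the amide link itself, since only the two ends of this change are in view, and a free primary amine on the same ethyl chain, a longer chain or a methyl ester on the carbonyl carbon would help separate these. Going by these compounds, compounds 1 and 3 differ from compound 4 in more than one place, so it also remains open how hydroxy on the carbonyl carbon would compare with the methylpiperazinyl amide when the rest of the molecule is held the same.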